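Ring size of an ester group in furyl dihydropyrimidinones

The source may hold more compounds than are shown below. What is called first, only, known or untested is meant among the compounds shown, and "the series" means these compounds.

Compound 1 `CC1=C(C(=O)OCC2CC2)C(c2ccco2)NC(=O)N1` is the starting point of this small series. In an assay on membranes from HEK293 cells for displacement of a labelled ligand from adenosine receptor A2b (Homo sapiens), read by scintillation counting, with a stated time of 30 min (a lower number here means a stronger inhibitor, a higher number a weaker inhibitor), compound 1 gives 138 nM. Compound 2 `CC1=C(C(=O)OCC2CCC2)C(c2ccco2)NC(=O)N1` differs from it only by cyclobutyl in place of cyclopropyl on a saturated chain carbon bound to an oxygen next to a carbonyl group; in this assay compound 2 gives 561 nM, which is a 4.1-fold higher number from compound 1 to compound 2 (0.61 log units; beyond the scatter). Compound 3 `CC1=C(C(=O)OCC2CC2)C(c2ccoc2)NC(=O)N1` keeps the ester of compound 1 but carries a different core, the two cores differing by furan-3-yl in place of furan-2-yl on a saturated ring carbon. In this assay compound 3 gives 426 nM, a change of a 3.1-fold higher number from compound 1 to compound 3 (0.49 log units; beyond the scatter). Compound 2 and compound 3 therefore sit close to each other, with compound 1 the strongest inhibitor of the three measured.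

Compound 4 `CC1=C(C(=O)OCC2CCC2)C(c2ccoc2)NC(=O)N1` has not yet been measured. It differs from compound 3 by cyclobutyl in place of cyclopropyl on a saturated chain carbon bound to an oxygen next to a carbonyl group. This is the same change that was made from compound 1 to compound 2, at an identically described place, only now on the core of compound 3 instead of the core of compound 1. The change has been seen once so far, so the expectation rests on a single step, a 4.1-fold higher number from compound 1 to compound 2 (0.61 log units; beyond the scatter), applied to compound 3 with its value of 426 nM. On that basis the step for compound 4 is expected to be a 3.5-fold higher number from compound 3 to compound 4 (0.55 log units; beyond the scatter). Whether the two changes add up fully when combined on one molecule is not known from these data, so the range is kept wide. Compound 4 is therefore estimated to give 1500 nM in this assay, with a plausible span from 700 nM to 3500 nM.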

Compound 4, inhibition constant: 739 nM
For compound 4 the middle estimate is 2.0-fold (0.31 log units) above the measured one, within the range that was stated.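

With compound 4 measured, the swap of cyclopropyl for cyclobutyl on the core of compound 3 gives a 1.7-fold higher number from compound 3 to compound 4 (0.24 log units; within the scatter), and the swap of furan-2-yl for furan-3-yl with the cyclobutyl ester in place gives a 1.3-fold higher number from compound 2 to compound 4 (0.12 log units; within the scatter). Set beside its earlier step, the cyclobutyl swap shows no difference between the two cores that can be told from ordinary measurement scatter: the same change on two cores in this assay, a 4.1-fold higher number (0.61 log units; beyond the scatter) from compound 1 to compound 2 and a 1.7-fold higher number (0.24 log units; within the scatter) from compound 3 to compound 4, 2.3-fold (0.37 log units) apart, within the scatter of two such steps. Going by these compounds alone, the furan swap reads the same way, but with only one pair of steps per change, this shows that the four compounds cannot separate the steps, not that each change has exactly the same size on both cores: the same change on two cores in this assay, a 3.1-fold higher number (0.49 log units; beyond the scatter) from compound 1 to compound 3 and a 1.3-fold higher number (0.12 log units; within the scatter) from compound 2 to compound 4, 2.3-fold (0.37 log units) apart, within the scatter of two such steps.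

The compounds shown leave open how the number moves when the ester carries a cyclopentyl ring, a longer chain, an amine or a carboxylic acid in place of these small rings. They also leave open whether either swap gives a step of similar size on any core other than these two.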